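The source may hold more compounds than are shown below. What is called first, only, known or untested is meant among the compounds shown, and "the series" means these compounds.

In a functional assay on A549 cells (Homo sapiens) for inhibition, read by MTT assay, with a stated time of 48 h (a lower number here means a stronger inhibitor, a higher number a weaker inhibitor), three related compounds have been measured so far. Compound 1 `COc1ccc(N(C)c2nc(C)nc3ccccc23)cc1C(=O)OCCC[Se]C#N` gives 250 nM, the middle of the three numbers. Compound 2 `Cc1nc(N(C)c2ccc(OCC[Se]C#N)cc2)c2ccccc2n1` is weaker at 893 nM, and compound 3 `Cc1nc(N(C)c2ccc([Se]C#N)c(Cl)c2)c2ccccc2n1` is much stronger at 7 nM.

The next compound, compound 4 `COc1ccc(N(C)c2nc(C)nc3ccccc23)cc1[Se]C#N`, keeps the core of compound 1 and changes one place: a group of 3 heavy atoms (1 carbon, 1 nitrogen, 1 selenium; no ring) in place of a group of 9 heavy atoms (5 carbon, 1 nitrogen, 2 oxygen, 1 selenium; no ring), on an aromatic carbon. The new group sits on an aromatic carbon of a six-membered aromatic ring of carbon only, ortho to a methoxy group and meta to a large group.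

Among the measured compounds shown here, no measured pair differs in a single place, so the size of this step can only be judged loosely. The closest guide is compound 3, at 7 nM, which also carries this small group directly on an aromatic carbon. Compound 1 and compound 2 instead carry their selenium at the end of a chain, and both read higher. A clear drop is therefore expected, estimated as an 8.3-fold lower number from compound 1 to compound 4 (0.92 log units; beyond the scatter). For compound 4 the expected half-maximal inhibitory concentration is 30 nM, with an estimated range of 6 nM to 150 nM.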

Compound 4, half-maximal inhibitory concentration: 49 nM
Compound 4: the middle estimate sits 1.6-fold (0.21 log units) below what was measured; measured number inside the range.
By their numbers in this assay, from the lowest: compound 3; then compound 4; then compound 1; then compound 2.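

At this position, ortho to a methoxy group, replacing the ester-linked chain with the group of 3 heavy atoms gives a clear gain in this assay: a 5.1-fold lower number from compound 1 to compound 4 (0.71 log units; beyond the scatter). Among the compounds shown here, this is the first comparison that changes only one place, and it shows that the longer selenium-bearing chain is not needed for activity here, since the smaller group with selenium on the aromatic carbon gives the lower number. Nothing available explains this step.

On these data alone, the step removes the ester link and the carbon chain together, so the share of each in the change remains unknown. Also open, as far as these compounds go, is how a carboxylic acid, an amine, or a group with sulfur in place of selenium would read on this aromatic carbon.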